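Masking a diol on a quinone N-oxide series

A few compounds are considered here, and "the series" means these few. Any claim that something is new, unique, unknown or untested is made for them only; others in the source may bear on it.

Measured compounds:
Compound 1, `O=C1c2c[n+]([O-])c3ccccc3c2C(=O)c2c1c1ccccc1n2CCCCn1ccnc1`: 170 nM
Compound 2, `O=C1c2c[n+]([O-])c3ccccc3c2C(=O)c2c1c1ccccc1n2Cc1cn(C[C@H](O)CO)nn1`: 1030 nM

Both compounds were tested in a functional assay on A549 cells (Homo sapiens) for cytotoxicity, read by MTT assay, with a stated time of 72 h; on this read-out lower numbers stand for stronger inhibition and higher numbers for weaker inhibition. Going by the values given here, on these two numbers compound 2 stands highest, with compound 1 as its only neighbour; the lone step is a 6.1-fold higher number from compound 1 to compound 2 (0.78 log units; beyond the scatter).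

Compound 3, `CC1(C)OC[C@@H](Cn2cc(Cn3c4c(c5ccccc53)C(=O)c3c[n+]([O-])c5ccccc5c3C4=O)nn2)O1`, has not been measured. It differs from compound 2 only in one place: 2,2-dimethyl-1,3-dioxolan-4-yl in place of 1,2-dihydroxyethyl on a saturated chain carbon bound to an aromatic nitrogen. Among the compounds with values here, no measured step touches this change; the one step known swaps the whole group on the saturated chain carbon bound to the aromatic nitrogen, while here only the 1,2-dihydroxyethyl is replaced and the triazole stays. Within the data shown here, since the single known step was modest, a smaller move is expected here, in either direction, likely within the scatter, with a slight lean toward a lower number.

Compound 3 is therefore estimated at 700 nM, within 250 nM to 2000 nM, which is expected to correspond to a 1.5-fold lower number from compound 2 to compound 3 (0.17 log units; within the scatter).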

Compound 3, half-maximal inhibitory concentration: 4700 nM
Estimate against measurement, compound 3: 6.7-fold (0.83 log units) below; measured number above the stated range.
By their numbers in this assay, from the lowest: compound 1; then compound 2; then compound 3.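

In this assay, replacing 1,2-dihydroxyethyl with 2,2-dimethyl-1,3-dioxolan-4-yl on the saturated chain carbon bound to an aromatic nitrogen gives a 4.6-fold higher number from compound 2 to compound 3 (0.66 log units; beyond the scatter), so the number responds to this group even with the triazole unchanged. The earlier step swapped the whole group and could not show this; here the entering group has 0 hydrogen-bond donors against 2 in the group it replaces, with 2 hydrogen-bond acceptors in each. Nothing shown here indicates what lies behind the rise.

The compounds shown leave open how a single hydroxyl, an amine or a carboxylic acid in place of 1,2-dihydroxyethyl would read. They also leave open whether the opposite configuration at the defined stereocentre would move the number in either compound 2 or compound 3.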